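From Compound 1 to Compound 4: an Expected Step

The source may hold more compounds than are shown below. What is called first, only, known or untested is meant among the compounds shown, and "the series" means these compounds.

Compound 1 `O=C(NCCO)c1cccc2c1CCN2c1cc(Cc2cc(F)cc(C(F)(F)F)c2)ncn1` was tested in a functional assay on HEK293 cells for agonist activity at G-protein coupled receptor 52 (Homo sapiens), read by cAMP accumulation, with a stated time of 15 min (on this read-out lower numbers stand for an effect already at smaller amounts and higher numbers for an effect only at larger amounts of compound), where compound 1 gives 135 nM. This is the lowest of the three numbers recorded; compound 2 `O=C(NCCO)c1cccc2c1CCN2c1nccc(Cc2cc(F)cc(C(F)(F)F)c2)n1` gives 186 nM in this assay, a number within the scatter of compound 1, and compound 3 `Cc1c(Cc2cc(F)cc(C(F)(F)F)c2)cnnc1N1CCc2c(C(=O)NCCO)cccc21` gives 754 nM, a number beyond the scatter from compound 1. Compound 4 `O=C(NCCO)c1cccc2c1CCN2c1cc(Cc2ccc(C(F)(F)F)cc2)ncn1` differs from compound 1 in one place: 4-(trifluoromethyl)phenyl in place of 3-fluoro-5-(trifluoromethyl)phenyl on a saturated chain carbon bound to an aromatic carbon. For the measured compounds named here, no measured pair shows this change, so its effect cannot be read from the data. The author expects compound 4 to give a modestly higher number, a step of a 2.2-fold higher number from compound 1 to compound 4 (0.35 log units; beyond the scatter) in this assay that may not exceed the scatter. The estimate for compound 4 is 300 nM, within 80 nM to 1200 nM.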

Compound 4, half-maximal effective concentration: 109 nM
The estimate for compound 4 lay 2.8-fold (0.44 log units) above the measured number; low and high end bracket the measured number.
By their numbers in this assay, from the lowest: compounds 4, 1 and 2 (each within the scatter of the next); then compound 3.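

In this assay, for the compounds shown here, the step of a 1.2-fold lower number from compound 1 to compound 4 (0.09 log units; within the scatter) is the first reading at this position, since compounds 1, 2 and 3 all carry 3-fluoro-5-(trifluoromethyl)phenyl. The position thus accepts 4-(trifluoromethyl)phenyl with no change beyond the scatter, on the core of compound 1. No measurement shown explains this result.

This single step cannot separate the loss of fluorine from the different placement of trifluoromethyl. Also open, going by these compounds, is how the position responds to an unsubstituted phenyl, or to a nitrile or methoxy group in place of trifluoromethyl.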